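Aryl variation on the isoxazoline carbon: three measured, one pending

A few compounds are considered here, and "the series" means these few. Any claim that something is new, unique, unknown or untested is made for them only; others in the source may bear on it.

Measured so far:
compound 1 `COc1cc(-n2nnnc2-c2ccc(OCC3CC(c4cccc(Cl)c4)=NO3)c(N)c2)cc(OC)c1OC` — in a functional assay on MDA-MB-231 cells (Homo sapiens) for cytotoxicity, read by MTT assay, with a stated time of 48 h (a lower number here means a stronger inhibitor, a higher number a weaker inhibitor), compound 1 gives 2180 nM
compound 2 `COc1ccc(OC)c(C2=NOC(COc3ccc(-c4nnnn4-c4cc(OC)c(OC)c(OC)c4)cc3N)C2)c1` — in this assay compound 2 gives 3500 nM
compound 3 `COc1ccc(C2=NOC(COc3ccc(-c4nnnn4-c4cc(OC)c(OC)c(OC)c4)cc3N)C2)cc1[N+](=O)[O-]` — in this assay compound 3 gives 3560 nM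

Compound 2 sits second highest of the three numbers, with a 1.0-fold higher number from compound 2 to compound 3 (0.01 log units; within the scatter) and a 1.6-fold higher number from compound 1 to compound 2 (0.21 log units; within the scatter), both within the scatter; a 1.6-fold higher number from compound 1 to compound 3 (0.21 log units; within the scatter) is within the scatter as well. Compound 4 `COc1cc(C2=NOC(COc3ccc(-c4nnnn4-c4cc(OC)c(OC)c(OC)c4)cc3N)C2)ccc1O` differs from compound 2 by 4-hydroxy-3-methoxyphenyl in place of 2,5-dimethoxyphenyl on a carbon with a double bond to nitrogen. The three measured steps all swap the aryl group at this same place and none moved the number beyond the scatter, so no step beyond the scatter is expected for compound 4 in this assay either. Compound 4 is therefore expected to give about 3000 nM, within 1400 nM to 6500 nM, which means an expected step of a 1.2-fold lower number from compound 2 to compound 4 (0.07 log units; within the scatter).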

Compound 4, half-maximal inhibitory concentration: 3620 nM
For compound 4 the middle estimate is 1.2-fold (0.08 log units) below the measured one; the measured number falls inside the stated range.
By their numbers in this assay, from the lowest: compounds 1, 2, 3 and 4 (each within the scatter of the next).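

Compound 4, with 4-hydroxy-3-methoxyphenyl, is the only one of the four whose aryl group carries a hydrogen-bond donor, yet in this assay all three new steps stay within the scatter: a 1.0-fold higher number from compound 2 to compound 4 (0.01 log units; within the scatter), a 1.0-fold higher number from compound 3 to compound 4 (0.01 log units; within the scatter) and a 1.7-fold higher number from compound 1 to compound 4 (0.22 log units; within the scatter). At this position, adding the donor therefore gives no step beyond the scatter against any of the three other aryl groups. No available evidence bears on this result.

Still open, on these data alone, is whether an amine or a carboxylic acid on this aryl group would give a step beyond the scatter. The same question applies to a longer alkyl chain in place of the aryl group.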